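From 4-fluorobenzyl to 3-chlorobenzyl on a shared core

The compounds below may be only part of what the source reports. "The series", "measured", "known", "first", "only" and "open" are said of these compounds alone.

Three compounds built on one shared core frame this account: compound 1 (`COC(=O)c1ccc(NCc2cncn2Cc2ccccc2-c2ccccc2)cc1-c1ccccc1`), compound 2 (`COC(=O)c1ccc(NCc2cncn2Cc2ccccc2Br)cc1-c1ccccc1`) and compound 3 (`COC(=O)c1ccc(NCc2cncn2Cc2ccc(F)cc2)cc1-c1ccccc1`). Going by the values given here, in a toxicity assay on NIH3T3 cells (Mus musculus) for cytotoxicity, read by resazurin assay (a lower number here means that less compound is needed, a higher number that more compound is needed for the effect), compound 2 gives 10000 nM, the only single number among them. The entry for compound 1 reads "not determined" (no result reported). The entry for compound 3 reads "not determined" (no result reported), so compound 3 has no place on the scale and cannot be ranked against compound 2.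

The open question concerns compound 4 (`COC(=O)c1ccc(NCc2cncn2Cc2cccc(Cl)c2)cc1-c1ccccc1`), which has not yet been measured. The structural change is 3-chlorophenyl in place of 4-fluorophenyl on a saturated chain carbon bound to an aromatic nitrogen. It puts 3-chlorophenyl in place of 4-fluorophenyl on a saturated chain carbon bound to an aromatic nitrogen, and cut one bond further out it reads 4-fluorobenzyl to 3-chlorobenzyl.

Among the compounds with values here, no measured pair shows what a change at this place does in this assay, and compound 3 offers no number to step from. Within the data shown here, the only anchor is compound 2 at 10000 nM, and it suggests no direction. The expectation is therefore a result close to that anchor, with no step beyond the scatter. Compound 4 is estimated at 10000 nM, with an expected range from 3000 nM to 30000 nM.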

Compound 4, half-maximal effective concentration: > 10000 nM
Compound 4: no number, only a limit; the forecaster's own chance of this, stated with the estimate: 35%; the middle value lies on the limit itself.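

In this assay compound 4 gives > 10000 nM, which is a limit of the assay and not a number, and it is the only entry shown with 3-chlorophenyl on the saturated chain carbon bound to an aromatic nitrogen. With 3-chlorophenyl in place of 2-bromophenyl, the reading is a number no lower from compound 2 to compound 4 (the limit leaves the size open), so this place now carries one step with a stated direction, although its size cannot be read. Compound 3 offers no number, so the change from 4-fluorophenyl to 3-chlorophenyl yields no comparison, and the one new reading at this place is bounded on one side only: the limit of > 10000 nM in this assay, at which 1 of the 4 values shown sits.

The compounds shown leave open how far the values at this place extend, since the single value and the limit give no size for any change there. Whether a carboxylic acid or an amine on this phenyl ring, in place of the halogen, would give a single number rather than a limit in this assay also remains an open question.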